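Compound 2 to compound 3: one aryl group exchanged

A few compounds are considered here, and "the series" means these few. Any claim that something is new, unique, unknown or untested is made for them only; others in the source may bear on it.

In a functional assay on HCT-116 cells (Homo sapiens) for antiproliferative activity, read by MTT assay, with a stated time of 72 h (a lower number here means a stronger inhibitor, a higher number a weaker inhibitor), compound 1 `CCNC(=O)CCc1cccc2c1B(O)OC2` reads > 100000 nM as a limit of the assay, not a number. Among the measured compounds shown here, compound 2 `COc1cccc(-c2cccc(NC(=O)CCc3ccc4c(c3)COB4O)c2)c1` gives 81000 nM and holds the only true number so far, a weak value. Compound 3 `CC(=O)c1ccc(-c2cccc(NC(=O)CCc3ccc4c(c3)COB4O)c2)cc1` differs by 4-acetylphenyl in place of 3-methoxyphenyl on an aromatic carbon with 4-acetylphenyl in place of 3-methoxyphenyl on an aromatic carbon. No measured step sizes such an exchange, so no direction is expected in this assay and the estimated step of a 1.2-fold lower number from compound 2 to compound 3 (0.06 log units; within the scatter) stays within the scatter. Compound 3 is estimated at 70000 nM with an expected range from 30000 nM to 100000 nM in this assay.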

Compound 3, half-maximal inhibitory concentration: 63000 nM
Estimate against measurement, compound 3: 1.1-fold (0.05 log units) above, within the range that was stated.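

In this assay, among the compounds shown here, 4-acetylphenyl in place of 3-methoxyphenyl on this aromatic carbon gives a 1.3-fold lower number from compound 2 to compound 3 (0.11 log units; within the scatter), the first measured step at this position. The two aryl groups are not separated by this step, and both compounds remain weak. Little room remains at the top of the measurable range: the limit of > 100000 nM in this assay, at which 1 of the 3 values shown sits.

On these data alone, whether an amine or a carboxylic acid on this aryl ring would move the number beyond the scatter remains open. The shown pair also cannot separate the identity of the aryl substituent from where it sits on the ring.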